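Swapping the aryl group on a chalcone-like ketone

The source may report more compounds than this note shows. Statements on the series, on what has been measured and on what is new or still open speak of the compounds shown alone.

Of the compounds shown here, three sharing one core have been tested in a functional assay on SF-268 cells (Homo sapiens) for cytotoxicity, read by sulforhodamine B assay, with a stated time of 48 h, tested at 10 uM; a higher number here means a weaker effect of the compound at the concentration tested, a lower number a stronger effect. Compound 1 `COc1cc(-c2cc(/C=C/C(=O)c3ccc(Cl)c(Cl)c3)[nH]n2)cc(OC)c1OC` carries a 3,4-dichlorophenyl on its carbonyl carbon and gives 60%. Compound 2 `COc1ccc(C(=O)/C=C/c2cc(-c3cc(OC)c(OC)c(OC)c3)n[nH]2)cc1OC` gives -60%, and compound 3 `COc1ccc(C(=O)/C=C/c2cc(-c3cc(OC)c(OC)c(OC)c3)n[nH]2)cc1` gives -35%. Among these three numbers compound 3 stands second highest: its nearest neighbour is compound 2, a number 25 percentage points higher from compound 2 to compound 3 (beyond the scatter), and the furthest is compound 1, a number 95 percentage points lower from compound 1 to compound 3 (beyond the scatter).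

Compound 4 `COc1cc(-c2cc(/C=C/C(=O)c3ccc(F)c(F)c3)[nH]n2)cc(OC)c1OC` differs from compound 3 in one place: 3,4-difluorophenyl in place of 4-methoxyphenyl on a carbonyl carbon. Among the measured compounds shown here, the measured step that bears most directly on this change is the one a number 95 percentage points lower from compound 1 to compound 3 (beyond the scatter), where a 4-methoxyphenyl replaced a 3,4-dichlorophenyl; the present change runs the other way, bringing in a phenyl with two halogens. The step of a number 120 percentage points lower from compound 1 to compound 2 (beyond the scatter) points the same way. A rise in this assay is therefore expected, though a 3,4-difluorophenyl is not a 3,4-dichlorophenyl, so the full size of the earlier step need not be recovered. Compound 4 is expected to land at 30%, between -10% and 70%, meaning an expected step of a number 65 percentage points higher from compound 3 to compound 4 (beyond the scatter).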

Compound 4, a percentage reported as activity, at one concentration (the size of the read-out at that concentration, not a potency): 17%
Compound 4: middle estimate off by 13 percentage points, on the high side; the range from low to high includes it.
By their numbers in this assay, from the lowest: compound 2; then compound 3; then compound 4; then compound 1.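

Replacing the 4-methoxyphenyl on the carbonyl carbon with a 3,4-difluorophenyl gives a number 52 percentage points higher from compound 3 to compound 4 (beyond the scatter) in this assay, and replacing the 3,4-dimethoxyphenyl with the same group gives a number 77 percentage points higher from compound 2 to compound 4 (beyond the scatter), so the difluorinated compound has a weaker effect at the concentration tested than either methoxy-bearing compound. Yet the halogens are not interchangeable at this position: exchanging the 3,4-dichlorophenyl for the 3,4-difluorophenyl gives a number 43 percentage points lower from compound 1 to compound 4 (beyond the scatter), which places the difluorinated compound on the stronger side of the dichlorinated one. Among these four compounds, the result therefore depends on which halogen is present, not merely on whether the phenyl carries halogens or methoxy groups, and no measurement at hand explains this order.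

From the compounds shown here alone, it remains open how a 4-fluorophenyl or 4-chlorophenyl would compare with the groups carrying two halogens, which would show whether a single halogen gives a similar reading. Going by these compounds, it is also open whether a 3,4-dibromophenyl would extend the trend from fluorine to chlorine, and how a phenyl bearing an amine or a carboxylic acid would behave at this carbonyl carbon.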